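This account rests on a few compounds, and the source may have more. Where it says the series, first, only, none or still open, it means among the compounds named here.

Values so far in a physicochemical assay for solubility, at pH 7.4; on this read-out lower numbers stand for lower solubility and higher numbers for higher solubility:
compound 1 `Cc1cc(NC(=O)Nc2ccccc2OC(F)(F)F)c2ccccc2n1` gives 4600 nM
compound 2 `CCc1ccc(NC(=O)Nc2cc(C)nc3ccccc23)cc1` gives 3300 nM
compound 3 `Cc1cc(NC(=O)Nc2ccccc2C(C)(C)C)c2ccccc2n1` gives 100 nM

Compound 2 at 3300 nM lies within the scatter of compound 1 at 4600 nM and well above compound 3 at 100 nM on this scale. Going from compound 2 to compound 4 `Cc1cc(NC(=O)Nc2ccc(F)cc2)c2ccccc2n1` the change is fluoro in place of ethyl on an aromatic carbon and in words it is fluoro in place of ethyl on an aromatic carbon. Among the compounds with values here, only one measured step bears on this, and only loosely: a 46-fold lower number from compound 1 to compound 3 (1.66 log units; beyond the scatter) with tert-butyl in place of trifluoromethoxy on an aromatic carbon. Within the data shown here, that step was large, but neither ethyl nor fluoro takes part in it, and no measured step exchanges these two groups. No step beyond the scatter is therefore expected in this assay in either direction, although the uncertainty is wide. The expected change is a 1.2-fold higher number from compound 2 to compound 4 (0.08 log units; within the scatter) as estimated here. For compound 4 the estimated value is 4000 nM with an expected range from 1200 nM to 13000 nM on this read-out.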

Compound 4, solubility: 3700 nM
Estimate against measurement, compound 4: 1.1-fold (0.03 log units) above; the range from low to high includes it.
By their numbers in this assay, from the lowest: compound 3; then compounds 2, 4 and 1 (each within the scatter of the next).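

In this assay, the exchange of ethyl for fluoro on an aromatic carbon, para to a large group, gives a step within the scatter (a 1.1-fold higher number from compound 2 to compound 4 (0.05 log units; within the scatter)), so the read-out does not separate these two groups at this position. Within the data shown here, the only earlier step (a 46-fold lower number from compound 1 to compound 3 (1.66 log units; beyond the scatter)) was large, but it exchanged trifluoromethoxy for tert-butyl, so it said nothing about ethyl, fluoro or this position; the new pair shows that a change in this place, from two heavy atoms to one, need not bring a large step. No measurement on hand explains why the two groups are not separated here. On these data alone, whether an amine, a carboxylic acid or a longer chain such as butyl in this place would also stay within the scatter remains open. So does whether tert-butyl or trifluoromethoxy would give a large step here.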